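Bromo to fluoro on the core of compound 1

A few compounds are considered here, and "the series" means these few. Any claim that something is new, unique, unknown or untested is made for them only; others in the source may bear on it.

Compound 1 `Cc1c(Br)cc(C(=O)NC2CCCCCC2)c(=O)n1Cc1ccc(F)cc1`: in an assay on HEK293 cells for inhibition of Lysophosphatidylserine lipase ABHD12 (Homo sapiens), read by scintillation counting, with stated times of 30 min and 5 min (a lower number here means a stronger inhibitor, a higher number a weaker inhibitor), compound 1 gives > 10000 nM, a limit of the assay.
Compound 2 `Cc1c(Br)cc(C(=O)NC2CCNCC2)c(=O)n1Cc1ccc(F)cc1`: in this assay compound 2 gives > 10000 nM, likewise a limit of the assay.

Compound 1 therefore stands at the limit only; no number is known for it. Going by the values given here, the one measured step, a step that the two limits leave unreadable from compound 1 to compound 2, cannot be read, since (the limit of > 10000 nM in this assay, at which 2 of the 2 values shown sit).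

Compound 3 `Cc1c(F)cc(C(=O)NC2CCCCCC2)c(=O)n1Cc1ccc(F)cc1` differs from compound 1 by fluoro in place of bromo on an aromatic carbon. Among the compounds with values here, no measured step bears on this change: the only comparison available sits at the limit on both sides and tells nothing about size or direction. Nothing among the shown values therefore supports an expectation of any step beyond the scatter in this assay, and the most likely outcome for compound 3 is again a limit.

Compound 3 is accordingly estimated at 20000 nM, within 4000 nM to 100000 nM, which means an expected step that the limit leaves unreadable from compound 1 to compound 3.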

Compound 3, half-maximal inhibitory concentration: > 10000 nM
Compound 3 was reported as a limit; the forecaster's own chance of this, stated with the estimate: 80%; the middle value lies beyond the limit too.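

Compound 1 and compound 3 both stand at a limit in this assay, so no step can be read for fluoro in place of bromo on the core: the limit of > 10000 nM in this assay, at which 3 of the 3 values shown sit.

The compounds shown leave open whether this exchange changes inhibition at all, and in which direction.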